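This account rests on a few compounds, and the source may have more. Where it says the series, first, only, none or still open, it means among the compounds named here.

Of the compounds shown here, three have so far been measured in a functional assay on NCI-H520 cells (Homo sapiens) for inhibition, read by MTT assay, with a stated time of 48 h, tested at 10 uM; on this read-out lower numbers stand for less inhibition and higher numbers for more inhibition at the one concentration tested (going by the name of the read-out). Compound 1 `Cc1ccc(Nc2cc(NC(=O)Nc3c(Cl)cccc3Cl)ncn2)cc1F` gives 33.5% in this assay. Compound 2 `COc1ccc(F)cc1Nc1cc(NC(=O)Nc2c(Cl)cccc2Cl)ncn1` gives 38.1% in this assay. Compound 3 `COc1cc(NC(=O)Nc2cc(Nc3ccc(C)c(F)c3)ncn2)cc(OC)c1` gives 30.6% in this assay. Compound 4 `COc1cc(NC(=O)Nc2cc(Nc3cc(F)ccc3OC)ncn2)cc(OC)c1` has not yet been measured.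

From compound 1 to compound 2 the change is 5-fluoro-2-methoxyphenyl in place of 3-fluoro-4-methylphenyl on a nitrogen on an aromatic ring, and the read-out moves by a number 4.6 percentage points higher from compound 1 to compound 2 (within the scatter). Compound 3 and compound 1 carry different cores; the difference between the two cores is not broken down here. Among the compounds with values here, the change from compound 3 to compound 4 is 5-fluoro-2-methoxyphenyl in place of 3-fluoro-4-methylphenyl on a nitrogen on an aromatic ring, the same change as the one between compound 1 and compound 2, now made on the core of compound 3. Among the three measured compounds, the values of compound 3, compound 1 and compound 2 lie within the scatter of one another, so no ordering among them is drawn.

Within the data shown here, for compound 4 the expected step in this assay is a number 4.4 percentage points higher from compound 3 to compound 4 (within the scatter), resting on the earlier step of a number 4.6 percentage points higher from compound 1 to compound 2 (within the scatter) in this assay, which is the only prior instance of this change. Whether that step carries over to the core of compound 3 is not known from these data, so the range is kept wide. The estimate for compound 4 in this assay is 35%, expected to fall between 24% and 46%.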

Compound 4, a percentage reported as inhibition, at one concentration (the size of the read-out at that concentration, not a potency): 38%
Beside the measured number, compound 4's estimate is 3 percentage points below it; measured number inside the range.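

In this assay, 5-fluoro-2-methoxyphenyl in place of 3-fluoro-4-methylphenyl on a nitrogen on an aromatic ring can now be read on two cores, and the two steps do not differ: the same change on two cores in this assay, a number 4.6 percentage points higher (within the scatter) from compound 1 to compound 2 and a number 7.4 percentage points higher (within the scatter) from compound 3 to compound 4, 2.8 percentage points apart, within the scatter of two such steps. The new step, a number 7.4 percentage points higher from compound 3 to compound 4 (within the scatter), therefore fits a change that carries over between these two cores, but neither step on its own lies beyond the scatter, so the data do not show that this change raises the read-out on either core, and two cores support no rule for the wider series. The other new step, with 3,5-dimethoxyphenyl in place of 2,6-dichlorophenyl on an amide-type nitrogen, is a number 0.1 percentage points lower from compound 2 to compound 4 (within the scatter), so this exchange likewise shows no separation in the read-out, here with the 5-fluoro-2-methoxyphenyl group held constant.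

The compounds shown leave open how the read-out would respond to groups other than substituted phenyl rings at these two places, such as an amine or a carboxylic acid on the ring, or a longer chain on the amide-type nitrogen. All four values are also read-outs at a single concentration in one cell line, so they give no potency and no view of how far any of these steps holds in other cells.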